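Phenyl in place of the isopropylfuran on the amine carbon

This account rests on a few compounds, and the source may have more. Where it says the series, first, only, none or still open, it means among the compounds named here.

Measured so far:
compound 1 `CC[C@@H](Nc1n[s+]([O-])nc1Nc1cccc(C(=O)N(C)C)c1O)c1cc(C(C)C)co1` — 61 nM
compound 2 `Cc1cc([C@H](Nc2n[s+]([O-])nc2Nc2cccc(C(=O)N(C)C)c2O)C(C)C)oc1C` — 50 nM
compound 3 `Cc1ccc([C@H](NC2=NS(=O)(=O)N=C2Nc2cccc(C(=O)N(C)C)c2O)C2(C)CC2)o1` — 1100 nM

In an assay on isolated protein for binding affinity to C-X-C chemokine receptor type 1 (Homo sapiens) (a lower number here means a stronger inhibitor, a higher number a weaker inhibitor), compound 1 gives 61 nM, the second highest of the three numbers. Compound 2 gives 50 nM, which lies within the scatter of compound 1, so the two are not distinguished here. Compound 3 gives 1100 nM, well beyond the scatter and by far the highest number of the set.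

Compound 4 `CC[C@@H](Nc1n[s+]([O-])nc1Nc1cccc(C(=O)N(C)C)c1O)c1ccccc1` is not yet measured. It differs from compound 1 in one place: phenyl in place of 4-isopropylfuran-2-yl on a saturated chain carbon bound to a nitrogen on an aromatic ring and a saturated chain carbon. Going by the values given here, no step between measured compounds covers this change, so the size has to be guessed. Compound 1 at 61 nM and compound 2 at 50 nM both carry an alkyl-substituted furan at this carbon; the phenyl of compound 4 carries no substituent and is the smaller group. A modest rise in the number is expected, with a 2.5-fold higher number from compound 1 to compound 4 (0.39 log units; beyond the scatter) as the estimated step, though a result within the scatter would not surprise. Compound 4 is expected to give about 150 nM in this assay, within 50 nM to 500 nM.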

Compound 4, inhibition constant: 1220 nM
Compound 4: the middle estimate sits 8.1-fold (0.91 log units) below what was measured, outside the stated range (above it).
By their numbers in this assay, from the lowest: compounds 2 and 1 (each within the scatter of the next); then compounds 3 and 4 (each within the scatter of the next).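

Replacing 4-isopropylfuran-2-yl with phenyl on this saturated chain carbon gives, in this assay, a 20-fold higher number from compound 1 to compound 4 (1.30 log units; beyond the scatter), the first step shown at this position. The position is therefore far from indifferent to the group it carries, and the unsubstituted phenyl is not an equivalent replacement for the 4-isopropylfuran-2-yl of compound 1. Nothing available accounts for the size of this step.

The change replaces the furan ring and removes its isopropyl group in one move, so the step cannot be divided between the two. From the compounds shown here alone, it remains open whether a phenyl carrying an isopropyl group or an unsubstituted furan-2-yl at this carbon would read close to compound 1 or close to compound 4.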